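Swapping the amide's aryl ring: pyridine to imidazole

A few compounds are considered here, and "the series" means these few. Any claim that something is new, unique, unknown or untested is made for them only; others in the source may bear on it.

Measured so far in a functional assay on NCI-H1975 cells (Homo sapiens) for antiproliferative activity, read by MTT assay, with a stated time of 72 h; on this read-out lower numbers stand for stronger inhibition and higher numbers for weaker inhibition:
compound 1 `COc1ccc(C(=O)Nc2cc(Nc3nccc(-c4cn(C)c5ccccc45)n3)c(OC)cc2N(C)C)nc1` gives 2130 nM
compound 2 `COc1cc(N(C)C)c(NC(=O)c2ccccn2)cc1Nc1nccc(-c2cn(C)c3ccccc23)n1` gives 10400 nM

For the measured compounds named here, compound 2 stands with the highest number of the two, that is the weaker inhibitor; its nearest neighbour is compound 1, and the only step seen so far, a 4.9-fold higher number from compound 1 to compound 2 (0.69 log units; beyond the scatter), came from hydrogen in place of methoxy on an aromatic carbon. Compound 3 `COc1cc(N(C)C)c(NC(=O)c2c[nH]cn2)cc1Nc1nccc(-c2cn(C)c3ccccc23)n1` differs from compound 2 in another way: 1H-imidazol-4-yl in place of pyridin-2-yl on a carbonyl carbon. Going by the values given here, no measured pair differs in this way, so the step recorded between compounds 1 and 2 does not bear on it, and nothing here shows how exchanging the whole aryl ring of the amide plays out. With no guide in either direction, the expectation for the step from compound 2 to compound 3 is none beyond the scatter, a 1.3-fold lower number from compound 2 to compound 3 (0.11 log units; within the scatter). In this assay compound 3 is therefore estimated to give about 8000 nM, with a wide range from 2500 nM to 25000 nM.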

Compound 3, half-maximal inhibitory concentration: 3120 nM
Estimate against measurement, compound 3: 2.6-fold (0.41 log units) above, within the range that was stated.
By their numbers in this assay, from the lowest: compounds 1 and 3 (each within the scatter of the next); then compound 2.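

On the carbonyl carbon, the aryl ring of the amide can itself shift the result in this assay: replacing pyridin-2-yl with 1H-imidazol-4-yl gives a 3.3-fold lower number from compound 2 to compound 3 (0.52 log units; beyond the scatter), so a methoxy group on the pyridine is no longer the only change shown to matter here. The exchange of 5-methoxypyridin-2-yl for 1H-imidazol-4-yl gives a 1.5-fold higher number from compound 1 to compound 3 (0.17 log units; within the scatter), so these two groups cannot be told apart in this assay, even though one is a six-membered ring carrying methoxy and the other a smaller, unsubstituted five-membered ring. No measurement offered here explains why the ring exchange moves the number.

The exchange alters several things at once, including ring size, the count of ring nitrogens and the presence of a hydrogen-bond donor, so these two compounds cannot show which of those differences matters. From the compounds shown here alone, a 1-methyl-1H-imidazol-4-yl group, with a methyl group in place of the ring's hydrogen on nitrogen, or a plain phenyl ring would test this further, and whether a methoxy group on the imidazole would change the number also remains open.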